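Swapping the aryl substituent: tert-butyl to methoxy

A few compounds are considered here, and "the series" means these few. Any claim that something is new, unique, unknown or untested is made for them only; others in the source may bear on it.

Measured so far:
compound 1, `FC(F)(F)c1ccc(-c2ccc3c(NCCCNCc4ccco4)ccnc3c2)cc1`: 32000 nM
compound 2, `CC(C)Cc1ccc2c(NCCCNCc3ccco3)ccnc2c1`: 4200 nM
compound 3, `CC(C)(C)c1ccc(-c2ccc3c(NCCCNCc4ccco4)ccnc3c2)cc1`: 32000 nM

In a physicochemical assay for solubility, with a stated time of 18 h, at pH 7.4 (on this read-out higher numbers stand for higher solubility and lower numbers for lower solubility), compound 3 stands level with compound 1, and together they give the highest two of the three numbers. Compound 2 sits furthest away: a 7.6-fold higher number from compound 2 to compound 3 (0.88 log units; beyond the scatter). The shared core carries a propyl-linked furanylmethylamine side chain in all three, so the numbers differ only through the group on the aromatic carbon.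

Compound 4, `COc1ccc(-c2ccc3c(NCCCNCc4ccco4)ccnc3c2)cc1`, has not yet been measured. Its change from compound 3 is methoxy in place of tert-butyl on an aromatic carbon. The step that bears most on this is the earlier swap at the same place, no change at the digits printed from compound 1 to compound 3 (within the scatter), which moved nothing at the digits shown. The larger shifts, a 7.6-fold lower number from compound 1 to compound 2 (0.88 log units; beyond the scatter) and a 7.6-fold higher number from compound 2 to compound 3 (0.88 log units; beyond the scatter), concern a different kind of change, from a whole aryl group to isobutyl, and say less here.

A small step at most is therefore expected, a 1.3-fold higher number from compound 3 to compound 4 (0.10 log units; within the scatter), and for compound 4 the estimate in this assay is 40000 nM, within 15000 nM to 100000 nM.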

Compound 4, solubility: 32000 nM
Beside the measured number, compound 4's estimate is 1.3-fold (0.10 log units) above it, within the range that was stated.
By their numbers in this assay, from the lowest: compound 2; then compounds 1, 3 and 4 (each within the scatter of the next).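

Methoxy has fewer heavy atoms than tert-butyl and brings a hydrogen-bond acceptor that tert-butyl lacks, yet this assay shows no change at the digits printed from compound 3 to compound 4 (within the scatter). A second swap on the same aromatic carbon gives the same reading, no change at the digits printed from compound 1 to compound 4 (within the scatter), so trifluoromethyl, tert-butyl and methoxy cannot be told apart here, while the gap to the isobutyl compound stays at a 7.6-fold higher number from compound 2 to compound 4 (0.88 log units; beyond the scatter). Nothing measured here offers a reason for these readings.

Still open, going by these compounds, is whether this place stays as flat for a group of a different kind, such as an amine or a carboxylic acid, on the same aromatic carbon. Also open, on these data alone, is whether a longer chain in place of isobutyl would read closer to compound 2 or to the compounds that carry an aryl group.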